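Aryl swap on the ring nitrogen of aminothiophene ketones

The source may hold more compounds than are shown below. What is called first, only, known or untested is meant among the compounds shown, and "the series" means these compounds.

Compound 1: `COc1ccc(N2CCN(Cc3csc(N)c3C(=O)c3ccc(Cl)cc3)CC2)cc1` gives -52%
Compound 2: `Nc1scc(CN2CCN(c3cccc(F)c3F)CC2)c1C(=O)c1ccc(Cl)cc1` gives -79%

Of the compounds shown here, two have been measured in a functional assay on CHO cells with adenosine receptor A1 (Homo sapiens) as the target, read by cAMP accumulation and immunoassay, with a stated time of 6 min, tested at 10 uM; on this read-out lower numbers stand for a stronger effect and higher numbers for a weaker effect at the one concentration tested. Compound 1 `COc1ccc(N2CCN(Cc3csc(N)c3C(=O)c3ccc(Cl)cc3)CC2)cc1` gives -52%, while compound 2 `Nc1scc(CN2CCN(c3cccc(F)c3F)CC2)c1C(=O)c1ccc(Cl)cc1` gives -79%, the lowest of the two numbers. Among the compounds with values here, the single measured step, a number 27 percentage points lower from compound 1 to compound 2 (beyond the scatter), came from 2,3-difluorophenyl in place of 4-methoxyphenyl on an amine nitrogen in a ring and lies beyond the scatter.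

Compound 3 `Nc1scc(CN2CCN(c3cccc(Cl)c3)CC2)c1C(=O)c1ccc(Cl)cc1` is not yet measured. It differs from compound 2 by 3-chlorophenyl in place of 2,3-difluorophenyl on an amine nitrogen in a ring. Within the data shown here, the one measured step bears on the same position, and it shows that the aryl group on that ring nitrogen can move the number by a modest amount. Among the measured compounds shown here, nothing measured so far, however, separates a chlorine from two fluorines there, and compound 2 already stands at the lowest number seen. The step is therefore expected to be small and, if anything, toward a higher number, giving an expected a number 13 percentage points higher from compound 2 to compound 3 (beyond the scatter). For compound 3 the estimate in this assay is -66%, with a range from -90% to -40%.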

Compound 3, a percentage reported as activity, at one concentration (the size of the read-out at that concentration, not a potency): -77%
Compound 3: middle estimate off by 11 percentage points, on the high side; measured number inside the range.
By their numbers in this assay, from the lowest: compounds 2 and 3 (each within the scatter of the next); then compound 1.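

In this assay the exchange of 2,3-difluorophenyl for 3-chlorophenyl on the amine nitrogen in a ring gives a number 2 percentage points higher from compound 2 to compound 3 (within the scatter) and so leaves the two compounds indistinguishable, which shows that this position tolerates this change of halogen and of its count on the aryl ring without a readable shift. Set against the 4-methoxyphenyl of the first compound, 3-chlorophenyl gives a number 25 percentage points lower from compound 1 to compound 3 (beyond the scatter) and 2,3-difluorophenyl gives a number 27 percentage points lower from compound 1 to compound 2 (beyond the scatter), so among these three compounds the separation lies between compound 1 and the two halogen-bearing compounds, and it no longer rests on a single aryl group. Nothing at hand offers a reason for this likeness or for that separation.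

Because the only aryl group without a halogen here also carries its methoxy group in a different place, the compounds shown do not tell whether the substituent's kind or its place on the aryl ring matters, and a 3-methoxyphenyl or a plain phenyl would bear on that. As far as these compounds go, how a pyridine ring or a trifluoromethyl group on the aryl ring would read at this position also remains open.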